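A Methyl Added Where the Assay Already Saw Little

The source may hold more compounds than are shown below. What is called first, only, known or untested is meant among the compounds shown, and "the series" means these compounds.

Three compounds were measured in an ADME assay on HaCaT cells (Homo sapiens) for cytotoxicity, read by MTT assay, with a stated time of 48 h; a higher number here means a weaker inhibitor, a lower number a stronger inhibitor. Compound 1 `O=Cc1c(O)ccc2oc(-c3cccc(Cl)c3)nc12` gives 17800 nM in this assay. Compound 2 `COc1cc(OC)cc(-c2nc3c(C=O)c(O)ccc3o2)c1` gives 17600 nM in this assay. These two numbers sit within the usual scatter of each other, so neither can be called the weaker or the stronger one.

Compound 3 `CC(=O)c1c(O)ccc2oc(-c3ccccc3)nc12` stands apart, though not because of a number: in this assay compound 3 returns only a limit, > 30000 nM, meaning the assay could not resolve a value for it. Compound 3 thus stands at the limit of > 30000 nM in this assay, at which 1 of the 3 values shown sits, the ceiling of what this assay reports, and nothing more precise is known about it.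

Compound 4 `CC(=O)c1c(O)ccc2oc(-c3ccccc3C)nc12` has not yet been measured. It differs from compound 3 in one place: methyl in place of hydrogen on an aromatic carbon. Among the compounds with values here, no measured pair differs in a single place, so there is no step to compare this change against. Because compound 3 already sits at the limit of > 30000 nM in this assay, at which 1 of the 3 values shown sits, the expectation is that this change moves the value little if at all, and a second limit is more likely than a number. Compound 4 is expected to give about 30000 nM in this assay, with a range from 15000 nM to 60000 nM. The step of a number no higher from compound 3 to compound 4 (the limit leaves the size open) is therefore expected to stay within the scatter.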

Compound 4, half-maximal inhibitory concentration: 8940 nM
For compound 4 the middle estimate is 3.4-fold (0.53 log units) above the measured one, outside the stated range (below it).
By their numbers in this assay, from the lowest: compounds 4, 2 and 1 (each within the scatter of the next). At a limit, above all of these: compound 3.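

In this assay, a methyl on an aromatic carbon, ortho to a large group, gives an at least 3.3-fold lower number from compound 3 to compound 4 (0.52 log units; beyond the scatter), so this position is not silent: a single added carbon is enough to bring the series to a readable number, with compound 4 at 8940 nM. Within the data shown here, this is the only measured pair that differs in one place, so it is also the first direct sign that a change on this ring can make the number lower in this assay, though nothing here explains how it does so. Compound 3 remains only a limit, so the step has a smallest size but no known full size: the limit of > 30000 nM in this assay, at which 1 of the 4 values shown sits.

One pair cannot show whether the effect belongs to methyl itself or would appear with any group at this carbon, and an ethyl group, a longer chain, an amine or a carboxylic acid in the same place could each push the number further down or back up. From the compounds shown here alone, it also remains open whether a methyl on another carbon of the same ring would give a similar step.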